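The compounds below may be only part of what the source reports. "The series", "measured", "known", "first", "only" and "open" are said of these compounds alone.

Measured in an ADME assay on L6 cells (Rattus norvegicus) for cytotoxicity, with a stated time of 72 h; a lower number here means a stronger inhibitor, a higher number a weaker inhibitor:
- Compound 1 `CC(=O)OC1CC2(N(C)C)CC(c3ccccc3)C1C(c1ccccc1)C2`: "not determined" (no result reported)
- Compound 2 `CN(C)C12CC(OC(=O)CN3CCCC3)C(C(c3ccccc3)C1)C(c1ccccc1)C2`: 32700 nM

Among the compounds with values here, compound 1 has no result, so compound 2 holds the only number in this set. That leaves 32700 nM for compound 2 as a lone reference point, and it cannot be ranked against any other compound.

The next compound to be tested is compound 3 `CCN(CC)CC(=O)OC1CC2(N(C)C)CC(c3ccccc3)C1C(c1ccccc1)C2`, which keeps the shared core and differs from compound 2 in one place: diethylamino in place of pyrrolidin-1-yl on a saturated chain carbon bound to a carbonyl carbon. In words, diethylamino stands in place of pyrrolidin-1-yl on a saturated chain carbon bound to a carbonyl carbon, so a ring gives way to an open chain.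

Within the data shown here, no measured pair here shows what such a swap does in this assay. Any expectation must therefore start from compound 2 at 32700 nM. With no evidence for a direction, the expected change is a 1.1-fold lower number from compound 2 to compound 3 (0.04 log units; within the scatter), a step estimated to stay within the usual scatter of repeated measurements. For compound 3 the estimated value is 30000 nM, with an expected range of 12000 nM to 70000 nM.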

Compound 3, half-maximal inhibitory concentration: 30100 nM
For compound 3 the middle estimate is 1.0-fold (0.00 log units) below the measured one; low and high end bracket the measured number.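

In this assay, replacing the pyrrolidin-1-yl ring with open-chain diethylamino, on a saturated chain carbon bound to a carbonyl carbon, gives a 1.1-fold lower number from compound 2 to compound 3 (0.04 log units; within the scatter). The two groups have the same count of carbon and nitrogen atoms, so this pair isolates the difference between a closed ring and an open chain, and in this assay that difference does not separate compound 2 from compound 3. Nothing available here explains this result.

Both compounds with a number carry a tertiary amine with the same heavy-atom count at this place, so a single pair cannot show how far this tolerance extends, or whether it would hold for a smaller dimethylamino group, a morpholin-4-yl ring with its added oxygen, or a carboxylic acid in place of the amine. As far as these compounds go, it also remains open whether a longer chain between the carbonyl and the amine would shift the number beyond the usual scatter of repeated measurements.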